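This account rests on a few compounds, and the source may have more. Where it says the series, first, only, none or still open, it means among the compounds named here.

In a functional assay on SGC-7901 cells (Homo sapiens) for antiproliferative activity, read by MTT assay, with a stated time of 72 h (a lower number here means a stronger inhibitor, a higher number a weaker inhibitor), the series varies one aryl group on a shared core. Compound 1 (`COc1cc(-n2cnc3ccc(-c4ccc(C(C)=O)cc4)cc32)cc(OC)c1OC`) gives 450 nM, compound 2 (`COc1cc(-n2cnc3ccc(-c4ccc(C)cc4F)cc32)cc(OC)c1OC`) gives 5650 nM, and compound 3 (`COc1cc(-n2cnc3ccc(-c4cc(F)ccc4F)cc32)cc(OC)c1OC`) gives 6590 nM. Compound 3 stands at the weak end of these numbers. Its gap to the nearest value, a 1.2-fold higher number from compound 2 to compound 3 (0.07 log units; within the scatter), lies within the scatter, while a 15-fold higher number from compound 1 to compound 3 (1.17 log units; beyond the scatter) is large, as is a 13-fold higher number from compound 1 to compound 2 (1.10 log units; beyond the scatter).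

Compound 4 (`COc1cc(-n2cnc3ccc(-c4ccc([N+](=O)[O-])cc4)cc32)cc(OC)c1OC`) follows from 4-nitrophenyl in place of 2,5-difluorophenyl on an aromatic carbon, with 4-nitrophenyl in place of 2,5-difluorophenyl on an aromatic carbon. Among the measured compounds shown here, no measured step covers this group. The closest guide is compound 1 at 450 nM, whose 4-acetylphenyl, like 4-nitrophenyl, carries no fluorine, whereas both fluorine-bearing groups sit at the weak end. For the measured compounds named here, with only three compounds, this is a thin basis, so only part of the large gap is expected to be recovered. In this assay, the expected move is towards a lower number, with an estimated 6.6-fold lower number from compound 3 to compound 4 (0.82 log units; beyond the scatter). The estimate for compound 4 is 1000 nM, with an expected range of 300 nM to 3500 nM.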

Compound 4, half-maximal inhibitory concentration: 79 nM
The estimate for compound 4 lay 13-fold (1.10 log units) above the measured number, outside the stated range (below it).
By their numbers in this assay, from the lowest: compound 4; then compound 1; then compounds 2 and 3 (each within the scatter of the next).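

In this assay, this position spans a much wider range than the first three compounds showed: an 83-fold lower number from compound 3 to compound 4 (1.92 log units; beyond the scatter) and a 72-fold lower number from compound 2 to compound 4 (1.85 log units; beyond the scatter) are both large, and compound 4 is now the strongest of the four. The step between the two groups without fluorine, nitro in place of acetyl, is smaller but still beyond the scatter at a 5.7-fold lower number from compound 1 to compound 4 (0.76 log units; beyond the scatter), so the identity of that substituent matters even with fluorine absent from both. Nothing available explains why 4-nitrophenyl stands apart from the other aryl groups.

From the compounds shown here alone, the fluorine-bearing groups differ from 4-nitrophenyl in more than one substituent, so the separate contributions of losing fluorine and adding nitro remain open. Also open, going by these compounds, is how a nitrile, an amine or a carboxylic acid on this aryl ring would read in this assay.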